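Dropping a Methyl from the Sulfonamide Aryl Group

The compounds below may be only part of what the source reports. "The series", "measured", "known", "first", "only" and "open" are said of these compounds alone.

Compound 1 `O=C1NCCN1c1ccc(S(=O)(=O)Nc2ccc(F)c(F)c2)cc1`: 350 nM
Compound 2 `Cc1cccc(NS(=O)(=O)c2ccc(N3CCNC3=O)cc2)c1C`: 190 nM
Compound 3 `Cc1ccc(NS(=O)(=O)c2ccc(N3CCNC3=O)cc2)c(C)c1`: 180 nM

These three compounds were tested in a functional assay on HT-29 cells (Homo sapiens) for antiproliferative activity, read by sulforhodamine B assay, with a stated time of 48 h; a higher number here means a weaker inhibitor, a lower number a stronger inhibitor. Among the measured compounds shown here, compound 3 has the lowest number of the three, yet the steps of a 1.9-fold lower number from compound 1 to compound 3 (0.29 log units; within the scatter) and a 1.1-fold lower number from compound 2 to compound 3 (0.02 log units; within the scatter) both lie within the scatter, so no compound can be called the strongest. Compound 4 `Cc1cccc(NS(=O)(=O)c2ccc(N3CCNC3=O)cc2)c1` has not been measured. It differs from compound 3 in one place: 3-methylphenyl in place of 2,4-dimethylphenyl on a sulfonamide nitrogen. For the measured compounds named here, the steps that bear on this change are the earlier swaps of groups on the same sulfonamide nitrogen, a 1.8-fold lower number from compound 1 to compound 2 (0.27 log units; within the scatter), a 1.9-fold lower number from compound 1 to compound 3 (0.29 log units; within the scatter) and a 1.1-fold lower number from compound 2 to compound 3 (0.02 log units; within the scatter), none of them beyond the scatter. A shift beyond the scatter in this assay is therefore not expected, and the estimated step is a 1.2-fold higher number from compound 3 to compound 4 (0.09 log units; within the scatter). Compound 4 is expected to give about 220 nM, between 110 nM and 450 nM.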

Compound 4, half-maximal inhibitory concentration: 110 nM
Beside the measured number, compound 4's estimate is 2.0-fold (0.30 log units) above it; the measured number falls inside the stated range.
By their numbers in this assay, from the lowest: compounds 4, 3, 2 and 1 (each within the scatter of the next, the first and the last beyond it).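

On the sulfonamide nitrogen in this assay, one methyl serves as well as two: 3-methylphenyl in place of 2,4-dimethylphenyl (a 1.6-fold lower number from compound 3 to compound 4 (0.21 log units; within the scatter)) and hydrogen in place of methyl on an aromatic carbon (a 1.7-fold lower number from compound 2 to compound 4 (0.24 log units; within the scatter)) both stay small. Among the compounds shown here, for the first time, a step at this position passes the scatter, with 3-methylphenyl in place of 3,4-difluorophenyl (a 3.2-fold lower number from compound 1 to compound 4 (0.50 log units; beyond the scatter)). Nothing measured here explains these differences. From the compounds shown here alone, it remains open whether plain phenyl, or a methoxy or amine on this ring, would match 3-methylphenyl.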